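Removing one methoxy group: a repeated step

A few compounds are considered here, and "the series" means these few. Any claim that something is new, unique, unknown or untested is made for them only; others in the source may bear on it.

Compound 1 `COc1cc(-c2cc(/C=C/C(=O)c3ccc(N)cc3)[nH]n2)cc(OC)c1OC` and compound 2 `COc1ccc(-c2cc(/C=C/C(=O)c3ccc(N)cc3)[nH]n2)cc1OC` share a core, and compound 2 differs from compound 1 only by hydrogen in place of methoxy on an aromatic carbon. In a functional assay on MOLT-4 cells (Homo sapiens) for cytotoxicity, read by sulforhodamine B assay, with a stated time of 48 h, tested at 10 uM (on this read-out lower numbers stand for a stronger effect and higher numbers for a weaker effect at the one concentration tested), compound 1 gives -5%, while compound 2 gives 6%, so that change made a number 11 percentage points higher from compound 1 to compound 2 (beyond the scatter). Compound 3 `COc1cc(C(=O)/C=C/c2cc(-c3cc(OC)c(OC)c(OC)c3)n[nH]2)cc(OC)c1OC` is built on a different core; the difference between the two cores is not broken down here. In this assay compound 3 gives -4%. Compound 4 `COc1ccc(-c2cc(/C=C/C(=O)c3cc(OC)c(OC)c(OC)c3)[nH]n2)cc1OC` differs from compound 3 by hydrogen in place of methoxy on an aromatic carbon, the same change as before, at a place described in the same words. Compound 4 is therefore expected to lie near compound 3, shifted by about a number 8 percentage points higher from compound 3 to compound 4 (within the scatter), resting on the step from compound 1 to compound 2. The estimate for compound 4 is 4%, expected between -6% and 16%.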

Compound 4, a percentage reported as activity, at one concentration (the size of the read-out at that concentration, not a potency): -4%
Beside the measured number, compound 4's estimate is 8 percentage points above it; the measured number falls inside the stated range.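

In this assay, putting hydrogen in place of methoxy gives no change at the digits printed from compound 3 to compound 4 (within the scatter). Set beside the earlier step, the change cannot be said to behave differently on the two cores: the same change on two cores in this assay, a number 11 percentage points higher (beyond the scatter) from compound 1 to compound 2 and no change at the digits printed (within the scatter) from compound 3 to compound 4, 11 percentage points apart, within the scatter of two such steps. Among these compounds, this does not show that the change carries over with a fixed size, since only two pairs are available, only one of the two steps lies beyond the scatter, and each number comes from a single concentration, so it says nothing about potency.

The compounds shown leave open how other groups at this place, such as a hydroxyl group, a fluorine atom or a longer ethoxy chain, would read. They also leave open whether the same change would behave alike on further cores.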